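Weak inhibitors of a lipase: from amide to acetamido

This account rests on a few compounds, and the source may have more. Where it says the series, first, only, none or still open, it means among the compounds named here.

Going by the values given here, compound 2, `CCOc1ccc(-c2cccc(C(=O)N3CCCC3)c2)cc1`, stands at the higher end of the two numbers measured so far in an assay on COS-7 cells for inhibition of patatin-like phospholipase domain-containing protein 2 (Mus musculus); on this read-out higher numbers stand for weaker inhibition and lower numbers for stronger inhibition. Compound 2 gives 160000 nM in this assay. Among the compounds with values here, the only other measured compound, compound 1 with structure `CCCCOC(=O)c1cccc(-c2ccc(OCC)cc2)c1`, gives 100000 nM in this assay, and the step of a 1.6-fold higher number from compound 1 to compound 2 (0.20 log units; within the scatter) is the single measured step in the set. Compound 3, `CCOc1ccc(-c2cccc(NC(C)=O)c2)cc1`, has not yet been measured. The change from compound 2 to compound 3 is acetamido in place of (pyrrolidin-1-yl)carbonyl on an aromatic carbon. Within the data shown here, no measured step bears directly on this exchange; the one step available, from compound 1 to compound 2, concerns a different exchange on the carbonyl carbon and lay within the scatter. Both measured compounds sit at very weak inhibition, so the expectation for compound 3 is a step of a 1.1-fold lower number from compound 2 to compound 3 (0.03 log units; within the scatter), that is, no change beyond the scatter. Compound 3 is therefore estimated at 150000 nM in this assay, with a range from 50000 nM to 450000 nM.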

Compound 3, half-maximal inhibitory concentration: 200000 nM
Estimate against measurement, compound 3: 1.3-fold (0.12 log units) below; measured number inside the range.
By their numbers in this assay, from the lowest: compounds 1, 2 and 3 (each within the scatter of the next).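

On this aromatic carbon, the exchange of (pyrrolidin-1-yl)carbonyl for acetamido gives a 1.3-fold higher number from compound 2 to compound 3 (0.10 log units; within the scatter) in this assay, and the exchange of butoxycarbonyl for acetamido gives a 2.0-fold higher number from compound 1 to compound 3 (0.30 log units; within the scatter) in the same assay. Acetamido, with 4 heavy atoms, no ring and 1 hydrogen-bond donor, takes the place of a group of 7 heavy atoms with a five-membered non-aromatic ring and 0 hydrogen-bond donors, yet all three compounds remain within the scatter of the next, so this position has so far shown no measurable response to these differences in size, ring or donor count. No measured evidence is available to account for this flat result.

All three compounds remain at very weak inhibition, which leaves open whether any other group on this carbon, such as an amine, a carboxylic acid or an amide with a longer chain, would shift the number beyond the scatter. As far as these compounds go, it also remains open whether a change elsewhere on the shared core, such as a longer alkoxy chain in place of ethoxy, would have a larger effect than any exchange at this position.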